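This account rests on a few compounds, and the source may have more. Where it says the series, first, only, none or still open, it means among the compounds named here.

Measured compounds in a functional assay on the whole organism (Tail, strain ICR) with Mus musculus as the target, in the tail flick test, with a stated time of 150 min, at a dose of 25 umol/kg by the oral route; a lower number here means a weaker effect, a higher number a stronger effect of the compound at the dose given:
compound 1, `CSCC[C@H](NC(=O)CN(c1nc(Cl)nc2[nH]cnc12)C1CC1)C(=O)OCc1ccccc1`: 17.6%
compound 2, `CC[C@H](C)[C@H](NC(=O)CN(c1nc(Cl)nc2[nH]cnc12)C1CC1)C(=O)OCc1ccccc1`: 6.9%
compound 3, `O=C(CN(c1nc(Cl)nc2[nH]cnc12)C1CC1)NCC(=O)OCc1ccccc1`: 18%

Compound 3 holds the highest of the three numbers, but its gap to compound 1 is within the scatter; only compound 2 sits clearly lower. Compound 4, `O=C(CN(c1nc(Cl)nc2[nH]cnc12)C1CC1)N[C@@H](CCC(=O)OCc1ccccc1)C(=O)OCc1ccccc1`, differs from compound 3 by 2-(benzyloxycarbonyl)ethyl in place of hydrogen on a saturated chain carbon bound to an amide-type nitrogen and a carbonyl carbon. Among the compounds with values here, two measured steps bear on this position: a number 0.4 percentage points higher from compound 1 to compound 3 (within the scatter) and a number 11.1 percentage points higher from compound 2 to compound 3 (beyond the scatter). Replacing hydrogen at this carbon by a larger group thus gave either no change or a modest loss in this assay. For compound 4 a small downward step is therefore expected, a number 7 percentage points lower from compound 3 to compound 4 (within the scatter), with no change beyond the scatter also plausible. The estimate for compound 4 is 11%, within the range 3% to 24%.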

Compound 4, a percentage reported as activity, at one dose (the size of the read-out at that dose, not a potency): 44.5%
Compound 4: the middle estimate sits 33.5 percentage points below what was measured; the measured number lies above the stated range.
By their numbers in this assay, from the lowest: compound 2; then compounds 1 and 3 (each within the scatter of the next); then compound 4.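

In this assay, the saturated chain carbon bound to an amide-type nitrogen and a carbonyl carbon can carry a group that raises the read-out: 2-(benzyloxycarbonyl)ethyl in place of hydrogen gives a clear gain (a number 26.5 percentage points higher from compound 3 to compound 4 (beyond the scatter)). The same group also stands well clear of sec-butyl (a number 37.6 percentage points higher from compound 2 to compound 4 (beyond the scatter)), and benzyloxycarbonyl in place of methylsulfanyl gives a similar gain (a number 26.9 percentage points higher from compound 1 to compound 4 (beyond the scatter)), so size alone does not set the outcome here. Nothing available explains the gain.

Open, going by these compounds, is whether the gain needs the benzyl ester of this side chain or would survive with a free carboxylic acid there. Also open, on these data alone, is how a primary amine at the end of a similar chain would compare.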